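The source may report more compounds than this note shows. Statements on the series, on what has been measured and on what is new or still open speak of the compounds shown alone.

In a functional assay on KB cells (Homo sapiens) for inhibition, with a stated time of 72 h (on this read-out lower numbers stand for stronger inhibition and higher numbers for weaker inhibition), compound 1 `COc1ccc(S(=O)(=O)N2CCc3cccc(-c4ccco4)c32)cc1` gives 82 nM, compound 2 `COc1ccc(-c2cccc3c2N(S(=O)(=O)c2ccc(OC)cc2)CC3)cc1` gives 337 nM and compound 3 `COc1ccc(S(=O)(=O)N2CCc3cccc(-c4cccc(F)c4)c32)cc1` gives 98.5 nM. Compound 3 therefore stands level with compound 1 and clear of compound 2, the measured steps being a 1.2-fold higher number from compound 1 to compound 3 (0.08 log units; within the scatter) and a 3.4-fold lower number from compound 2 to compound 3 (0.53 log units; beyond the scatter). Compound 4 `COc1ccc(S(=O)(=O)N2CCc3cccc(-c4cccnc4)c32)cc1` carries pyridin-3-yl in place of 3-fluorophenyl on an aromatic carbon. Exchanges of this group have gone both ways: besides the steps above there is a 4.1-fold higher number from compound 1 to compound 2 (0.61 log units; beyond the scatter). Among the measured compounds shown here, no measured compound carries pyridin-3-yl, so only a small rise in the number, within the scatter, is expected, namely a 1.5-fold higher number from compound 3 to compound 4 (0.18 log units; within the scatter). Compound 4 is estimated at 150 nM, with an expected range from 55 nM to 420 nM.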

Compound 4, half-maximal inhibitory concentration: 95.9 nM
For compound 4 the middle estimate is 1.6-fold (0.19 log units) above the measured one; the measured number falls inside the stated range.
By their numbers in this assay, from the lowest: compounds 1, 4 and 3 (each within the scatter of the next); then compound 2.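

Pyridin-3-yl, which brings a ring nitrogen and a hydrogen-bond acceptor, takes the place of 3-fluorophenyl on this aromatic carbon with no step beyond the scatter (a 1.0-fold lower number from compound 3 to compound 4 (0.01 log units; within the scatter)), and the same holds against furan-2-yl (a 1.2-fold higher number from compound 1 to compound 4 (0.07 log units; within the scatter)). Among the compounds shown here, only the step from 4-methoxyphenyl (a 3.5-fold lower number from compound 2 to compound 4 (0.55 log units; beyond the scatter)) lies beyond the scatter, which leaves compound 2 alone apart from the other three compounds. No evidence here bears on why this is so. The compounds shown leave open whether pyridin-2-yl or pyridin-4-yl would match compound 4, and whether an amine or a carboxylic acid on this ring would be tolerated.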